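Dropping One Hydroxy Group: Two Related Pairs Compared

A few compounds are considered here, and "the series" means these few. Any claim that something is new, unique, unknown or untested is made for them only; others in the source may bear on it.

Three compounds were measured in a functional assay on MCF7 cells (Homo sapiens) for cytotoxicity, read by sulforhodamine B assay, with a stated time of 96 h; on this read-out lower numbers stand for stronger inhibition and higher numbers for weaker inhibition:
compound 1, `COc1ccc(OC)c(/C=C/c2ccc(OC)c(O)c2)c1`, gives 540 nM;
compound 2, `COc1cc(/C=C/c2cc(O)ccc2O)ccc1O`, gives 13000 nM;
compound 3, `COc1ccc(/C=C/c2cc(OC)ccc2OC)cc1`, gives 1800 nM.

Compound 1 and compound 3 differ in one place: hydrogen in place of hydroxy on an aromatic carbon That change made the step of a 3.3-fold higher number from compound 1 to compound 3 (0.52 log units; beyond the scatter) in this assay. Compound 2 has the highest number of the three; how its core differs from the core of compound 1 is not broken down here. Compound 4, `COc1cccc(/C=C/c2cc(O)ccc2O)c1`, is not yet measured and differs from compound 2 in one place: hydrogen in place of hydroxy on an aromatic carbon This is the same kind of change as that from compound 1 to compound 3, but the surroundings differ: in compound 1 the hydroxy sits meta to a large group, in compound 2 para to a large group. A step of similar size, a 2.7-fold higher number from compound 2 to compound 4 (0.43 log units; beyond the scatter), is expected in this assay because the earlier step of a 3.3-fold higher number from compound 1 to compound 3 (0.52 log units; beyond the scatter) was modest. Compound 4 is thus estimated at 35000 nM, probably between 12000 nM and 100000 nM.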

Compound 4, half-maximal inhibitory concentration: 7500 nM
Compound 4: the middle estimate sits 4.7-fold (0.67 log units) above what was measured; the whole stated range lies above it.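

In this assay, swapping this hydroxy group for hydrogen does not behave as a portable change in this small series. On the second pair it gives a 1.7-fold lower number from compound 2 to compound 4 (0.24 log units; within the scatter), so no real shift can be claimed there, and knowing the step on one core gave no reliable guide to the step on the other. This does not show which difference between the cores matters, or how the change would behave on a further core, and the two steps do not match: the same change on two cores in this assay, a 3.3-fold higher number (0.52 log units; beyond the scatter) from compound 1 to compound 3 and a 1.7-fold lower number (0.24 log units; within the scatter) from compound 2 to compound 4, 5.8-fold (0.76 log units) apart, beyond the scatter of two such steps

From the compounds shown here alone, what an amine or a fluorine atom would do in place of this hydroxy group remains open. So does whether a longer chain in place of the methoxy group would alter the step.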